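This account rests on a few compounds, and the source may have more. Where it says the series, first, only, none or still open, it means among the compounds named here.

Compound 1 `O=C(O)CCn1c(=O)oc2cc(OCC3CCC3)c(Cl)cc21` measures 12 nm/s
Compound 2 `O=C(O)CCn1c(=O)oc2cc(OCc3ccccn3)c(Cl)cc21` measures 11 nm/s

In a physicochemical assay for permeability, using PAMPA (a higher number here means that the compound crosses the layer faster, a lower number that the compound crosses the layer more slowly), compound 2 gives 11 nm/s, within the scatter of compound 1 at 12 nm/s. Compound 3 `C[C@@H](Oc1cc2oc(=O)n(CCC(=O)O)c2cc1Cl)c1ncco1` keeps the shared core and changes the group on the oxygen: a group of 7 heavy atoms (5 carbon, 1 nitrogen, 1 oxygen; one five-membered aromatic ring with 2 hetero atoms) in place of a group of 7 heavy atoms (6 carbon, 1 nitrogen; one six-membered aromatic ring with 1 hetero atom), on an oxygen on an aromatic ring. Within the data shown here, only one measured step bears on this change, a 1.1-fold lower number from compound 1 to compound 2 (0.04 log units; within the scatter), which also altered that side group and stayed within the scatter. No step beyond the scatter is therefore expected in this assay, although one step is thin evidence. The estimated step is no change at the digits printed from compound 2 to compound 3 (within the scatter). For compound 3 the expected value is 11 nm/s, with a range of 5 nm/s to 25 nm/s.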

Compound 3, apparent permeability: < 3 nm/s
Compound 3: only a limit was reported (the forecaster's own chance of this, stated with the estimate: 5%); middle value at least 3.6-fold (0.56 log units) away from the limit.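

The earlier side-group change stayed within the scatter, but this one does not: in this assay there is an at least 3.6-fold lower number from compound 2 to compound 3 (0.56 log units; beyond the scatter), and the cyclobutyl comparison gives an at least 4.0-fold lower number from compound 1 to compound 3 (0.60 log units; beyond the scatter). So the group on this oxygen can shift the read-out, even when the heavy-atom count stays the same as in compound 2. Compound 3 is reported only as a limit: the limit of < 3 nm/s in this assay, at which 1 of the 3 values shown sits.

The compounds shown do not separate the five-membered aromatic ring from the defined stereocentre that arrives with it. As far as these compounds go, how a side group carrying an amine would read at this position also remains open.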